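A few compounds are considered here, and "the series" means these few. Any claim that something is new, unique, unknown or untested is made for them only; others in the source may bear on it.

Compound 1: `COc1cc(-c2cc(/C=C/C(=O)c3ccc(N)cc3)[nH]n2)cc(OC)c1OC`, -71%
Compound 2: `COc1ccc(-c2cc(/C=C/C(=O)c3ccc(OC)c(OC)c3)[nH]n2)cc1`, -95%

In a functional assay on OVCAR-3 cells (Homo sapiens) for cytotoxicity, read by sulforhodamine B assay, with a stated time of 48 h, tested at 10 uM (a higher number here means a weaker effect of the compound at the concentration tested, a lower number a stronger effect), compound 1 gives -71%, the highest of the two numbers recorded. The nearest is compound 2 with -95%, a number lower by a gap that lies beyond the usual scatter, so compound 2 shows the stronger effect of the pair and compound 1 the weaker one.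

Compound 3, `COc1cc(-c2cc(/C=C/C(=O)c3ccc(F)c(F)c3)[nH]n2)cc(OC)c1OC`, has not yet been tested in this assay. It differs from compound 1 in one place: 3,4-difluorophenyl in place of 4-aminophenyl on a carbonyl carbon. Within the data shown here, no pair of measured compounds separated by this exchange exists, so neither the size nor the direction of the step can be read from the data. Compound 3 is therefore expected to remain close to compound 1, with an estimated step of a number 7 percentage points lower from compound 1 to compound 3 (within the scatter) that is small, no larger than the scatter, if anything toward a lower number. The estimate for compound 3 is -78%, between -100% and -50%.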

Compound 3, a percentage reported as activity, at one concentration (the size of the read-out at that concentration, not a potency): -24%
The estimate for compound 3 lay 54 percentage points below the measured number; measured number above the stated range.
By their numbers in this assay, from the lowest: compound 2; then compound 1; then compound 3.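

In this assay, putting 3,4-difluorophenyl in place of 4-aminophenyl on a carbonyl carbon is a large exchange in its effect, with a number 47 percentage points higher from compound 1 to compound 3 (beyond the scatter) and the rest of compound 1 unchanged. This position is therefore not indifferent to the group it carries, and this one exchange moves the result toward a weaker effect at the concentration tested. No measurement at hand accounts for this step.

The exchange removes the amine and adds two fluorines in one move, so the compounds shown leave open which of these changes goes with the step. An unsubstituted phenyl group would separate the two, and a 4-fluorophenyl or 4-(dimethylamino)phenyl group would show whether the step follows the fluorines or the hydrogens of the amine.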